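The source may hold more compounds than are shown below. What is called first, only, known or untested is meant among the compounds shown, and "the series" means these compounds.

Working notes on the series.

Three members of this series have been measured in a functional assay on PC-3 cells (Homo sapiens) for cytotoxicity, read by MTT assay, with a stated time of 48 h; a higher number here means a weaker inhibitor, a lower number a stronger inhibitor. Compound 1 `CNC(=O)c1cc(Oc2cccc(NC(=S)Nc3ccc(Cl)cc3)c2)ccn1` gives 24100 nM. Compound 2 `O=C(c1cc(Oc2cccc(NC(=S)Nc3cccc(C(F)(F)F)c3)c2)ccn1)N1CCCC1` gives 27000 nM. Compound 3 `CNC(=O)c1cc(Oc2cccc(NC(=S)Nc3ccc(OC(F)(F)F)cc3)c2)ccn1` gives 34700 nM, the highest of the three numbers, though the gap to compound 2 and the step of a 1.4-fold higher number from compound 1 to compound 3 (0.16 log units; within the scatter) both lie within the scatter, so the three compounds cannot be separated on these figures.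

Compound 4 `O=C(c1cc(Oc2cccc(NC(=S)Nc3ccc(OC(F)(F)F)cc3)c2)ccn1)N1CCCC1` is the next member: pyrrolidin-1-yl in place of methylamino on a carbonyl carbon. Among the measured compounds shown here, no single-point step exchanges these two groups directly. For the measured compounds named here, the only measured step, a 1.4-fold higher number from compound 1 to compound 3 (0.16 log units; within the scatter), concerns the other aromatic substituent and is within the scatter. Compound 2 carries the same (pyrrolidin-1-yl)carbonyl as compound 4, but with trifluoromethyl on the other ring, so it differs from compound 1 and compound 3 in two places; its value and that of compound 1 lie close together. Taken together, no step beyond the scatter is expected from compound 3 to compound 4, i.e. a 1.2-fold lower number from compound 3 to compound 4 (0.06 log units; within the scatter). Compound 4 is therefore estimated at 30000 nM, with a range of 15000 nM to 60000 nM in this assay.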

Compound 4, half-maximal inhibitory concentration: 34100 nM
Compound 4: the middle estimate sits 1.1-fold (0.06 log units) below what was measured; the range from low to high includes it.
By their numbers in this assay, from the lowest: compounds 1, 2, 4 and 3 (each within the scatter of the next).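

In this assay the exchange of methylamino for pyrrolidin-1-yl on a carbonyl carbon can now be read directly and gives a 1.0-fold lower number from compound 3 to compound 4 (0.01 log units; within the scatter), so the two compounds cannot be separated even though the amide hydrogen is gone and a five-membered non-aromatic ring has entered. With the (pyrrolidin-1-yl)carbonyl held constant, 4-(trifluoromethoxy)phenyl in place of 3-(trifluoromethyl)phenyl on an amide-type nitrogen gives a 1.3-fold higher number from compound 2 to compound 4 (0.10 log units; within the scatter) and so also leaves the two compounds inseparable. No measured evidence bearing on this result is at hand.

Going by these compounds, whether any group on this carbonyl carbon can take the number beyond the scatter remains open. A morpholin-4-yl, a 4-methylpiperazin-1-yl or an unsubstituted amino group in the same place would test this.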